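The source may report more compounds than this note shows. Statements on the series, on what has been measured and on what is new or still open speak of the compounds shown alone.

Two compounds of the series carry a result in a functional assay on the whole organism (strain Wistar) with Rattus norvegicus as the target, with a stated time of 5 min; a lower number here means that less compound is needed, a higher number that more compound is needed for the effect. Compound 2 `CCC1(CCCCN2CCN(c3ccc(Cl)cc3)CC2)C(=O)Nc2ccccc21` gives 10 mg/kg in this assay, and that is the only finite number shown for the series. Compound 1 `CCC1(CCCCN2CCN(c3cccc(Cl)c3)CC2)C(=O)Nc2cc(F)ccc21` reaches only > 20 mg/kg in this assay, which is a limit of the assay and not a number. Among the compounds with values here, the pair therefore shows one number and one limit; no step between the two is given, and the structures differ in more than one place, so nothing further is read from them.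

Compound 3 `CCC1(CCCCN2CCN(c3ccc(Cl)cc3)CC2)C(=O)Nc2cc(F)ccc21` is not yet measured. It differs from compound 2 by fluoro in place of hydrogen on an aromatic carbon. Compound 3 carries the same fluoro as compound 1 , and compound 1 sits at the limit of > 20 mg/kg in this assay, at which 1 of the 2 values shown sits. Within the data shown here, with no measured step available, the step from compound 2 to compound 3 is expected to be small and toward a higher dose, a 1.5-fold higher number from compound 2 to compound 3 (0.18 log units; within the scatter), close to the scatter. Compound 3 is estimated at 15 mg/kg in this assay, with a range of 5 mg/kg to 40 mg/kg. A fair chance remains that the assay records only a limit for compound 3 .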

Compound 3, minimum effective dose: > 20 mg/kg
Compound 3 ended at the assay's limit (the forecaster's own chance of this, stated with the estimate: 40%); middle value at least 1.3-fold (0.12 log units) away from the limit.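

Fluoro in place of hydrogen on the aromatic carbon meta to a fused ring and para to a fused ring gives the series its first comparison of a single change in this assay: an at least 2.0-fold higher number from compound 2 to compound 3 (0.30 log units; that floor lies within the scatter). From the compounds shown here alone, that floor lies within the scatter, so this pair does not establish a real loss at this position, and the true size of the step stays unknown. Compound 3 gives > 20 mg/kg, which is a limit of the assay, and the limit now holds most of the series: the limit of > 20 mg/kg in this assay, at which 2 of the 3 values shown sit.

The change from 3-chlorophenyl to 4-chlorophenyl between compound 1 and compound 3 cannot be read, as both values are limits. Open too, going by these compounds, is how chloro, methoxy or a nitrile on this same aromatic carbon would read against the hydrogen of compound 2, and whether a shorter chain on the shared core would change the result.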